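Replacing dimethylamino with methoxy: notes on compound 3

The source may hold more compounds than are shown below. What is called first, only, known or untested is meant among the compounds shown, and "the series" means these compounds.

Of the compounds shown here, two have numbers so far in a functional assay on the whole organism for inhibition, with Rattus norvegicus as the target; a higher number here means a weaker inhibitor, a lower number a stronger inhibitor. Compound 1 (`Cc1cc(O)cc(C)c1/C=C1\C(=O)ON=C1c1cccs1`) gives 1600 nM. Compound 2 (`CN(C)c1ccc(/C=C2\C(=O)ON=C2c2cccs2)cc1`) gives 4200 nM, the higher of the two numbers and so the weaker inhibitor, with its gap to compound 1 lying beyond the scatter.

Compound 3 (`COc1ccc(/C=C2\C(=O)ON=C2c2cccs2)cc1`) has methoxy in place of dimethylamino on an aromatic carbon, para to a large group: methoxy in place of dimethylamino on an aromatic carbon. Going by the values given here, no measured pair isolates this change, so the data give no direct guide to its size. The estimate therefore starts from compound 2 at 4200 nM. A change within the scatter is expected, leaning slightly towards a lower number. The expected step is a 1.4-fold lower number from compound 2 to compound 3 (0.15 log units; within the scatter). For compound 3 the expected value in this assay is 3000 nM, with an estimated range of 1200 nM to 7500 nM.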

Compound 3, half-maximal inhibitory concentration: 2500 nM
Compound 3: middle estimate off by 1.2-fold (0.08 log units), on the high side; the range from low to high includes it.
By their numbers in this assay, from the lowest: compounds 1, 3 and 2 (each within the scatter of the next, the first and the last beyond it).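

In this assay, going by these compounds alone, methoxy in place of dimethylamino on an aromatic carbon, para to a large group, gives a 1.7-fold lower number from compound 2 to compound 3 (0.23 log units; within the scatter) and this is the first step measured at this position. The assay does not separate the two groups, so dimethylamino is not needed here for the level of inhibition seen in compound 2. No measurement at hand bears on why the two groups fall so close.

On these data alone, whether this position stays as undemanding for other groups remains open, and a longer chain such as butoxy, a carboxylic acid or a primary amine in the same place would test it. As far as these compounds go, with a single step, it is also open whether this exchange gives a similar result elsewhere on the shared core.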